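The source may report more compounds than this note shows. Statements on the series, on what has been measured and on what is new or still open speak of the compounds shown alone.

Measured compounds in an in vitro assay on 293-EBNA cells for binding affinity to corticotropin-releasing factor receptor 1 (Homo sapiens); on this read-out higher numbers stand for weaker inhibition and lower numbers for stronger inhibition:

- compound 1 `COCC(C)(C)Nc1nc(C)nc2c1nnn2-c1ccc(C(C)C)cc1Br` gives 195 nM
- compound 2 `CCCC(CN(C)C)Nc1nc(C)nc2c1nnn2-c1ccc(C(C)C)cc1Br` gives 38.7 nM
- compound 3 `CCCCC(CC)Nc1nc(C)nc2c1nnn2-c1ccc(C(C)C)cc1Br` gives 3.1 nM

Compound 3 stands lowest of the three numbers: a 12-fold lower number from compound 2 to compound 3 (1.10 log units; beyond the scatter), and a 63-fold lower number from compound 1 to compound 3 (1.80 log units; beyond the scatter). Both steps into compound 3 exchange a chain that carries an oxygen or a nitrogen for an all-carbon chain on the nitrogen of the shared core, and both are large; the step of a 5.0-fold lower number from compound 1 to compound 2 (0.70 log units; beyond the scatter) is modest.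

Compound 4 `CCCCC(CCCC)Nc1nc(C)nc2c1nnn2-c1ccc(C(C)C)cc1Br` differs from compound 3 by ethyl in place of hydrogen on a saturated chain carbon, three bonds along the chain from a nitrogen on an aromatic ring. Among the compounds with values here, none of the measured steps lengthens an all-carbon chain at this position, so the two large steps bear on the change only indirectly: they show that the all-carbon chain of compound 3 gives the lowest number of the series, but they say nothing about whether further chain carbons move the number. The expectation for compound 4 in this assay is therefore a step within the scatter, in no particular direction, as an estimated step of a 1.1-fold higher number from compound 3 to compound 4 (0.05 log units; within the scatter). Compound 4 is expected to give about 3.5 nM, with a range from 1 nM to 12 nM.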

Compound 4, inhibition constant: 4.5 nM
For compound 4 the middle estimate is 1.3-fold (0.11 log units) below the measured one; measured number inside the range.
By their numbers in this assay, from the lowest: compounds 3 and 4 (each within the scatter of the next); then compound 2; then compound 1.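

In this assay, the change from 1-ethylpentyl to 1-butylpentyl gives a 1.5-fold higher number from compound 3 to compound 4 (0.16 log units; within the scatter), so ethyl in place of hydrogen at this saturated chain carbon leaves the number unresolved from that of compound 3. The second all-carbon chain also stays clear of the chains that carry a nitrogen or an oxygen, with an 8.6-fold lower number from compound 2 to compound 4 (0.93 log units; beyond the scatter) and a 43-fold lower number from compound 1 to compound 4 (1.64 log units; beyond the scatter), so the separation from those compounds does not rest on 1-ethylpentyl alone. No measurement on hand explains why the number holds across this change.

The compounds shown leave open how far the chain can grow at this carbon before the number moves, as with a hexyl chain in place of butyl. They also leave open whether a cyclohexyl ring, or a hydroxyl or dimethylamino group at the end of a butyl chain, would be accepted on this same branched frame.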